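The source may report more compounds than this note shows. Statements on the series, on what has been measured and on what is new or still open speak of the compounds shown alone.

The measured compounds and their numbers in a functional assay on Jurkat cells (Homo sapiens) for antiproliferative activity, read by MTT assay and trypan blue exclusion, with a stated time of 72 h; a lower number here means a stronger inhibitor, a higher number a weaker inhibitor:
Compound 1 `COC(=O)c1ccc(C2SCC(=O)N2c2ccc(N3CCN(Cc4ccc(Cl)c(Cl)c4)CC3)cn2)c(OC)c1`: compound 1 gives 61000 nM
Compound 2 `COC(=O)c1ccc(C2SCC(=O)N2c2ccc(N3CCN(S(=O)(=O)c4ccccc4)CC3)cn2)c(OC)c1`: compound 2 gives 52900 nM
Compound 3 `COC(=O)c1ccc(C2SCC(=O)N2c2ccc(N3CCNCC3)cn2)c(OC)c1`: compound 3 gives 19300 nM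

Compound 3 holds the lowest number of the three, the step to compound 2 and the step to compound 1 both lying beyond the scatter. Compound 4 `COC(=O)c1ccc(C2SCC(=O)N2c2ccc(N3CCN(S(=O)(=O)c4cc(Cl)ccc4Cl)CC3)cn2)c(OC)c1` differs from it in one place: (2,5-dichlorophenyl)sulfonyl in place of hydrogen on an amine nitrogen in a ring. Among the compounds with values here, two measured steps bear on this change, both running in the opposite direction, toward the free amine. From compound 2 to compound 3, a 2.7-fold lower number from compound 2 to compound 3 (0.44 log units; beyond the scatter), the loss of a phenylsulfonyl group lowered the number modestly; from compound 1 to compound 3, a 3.2-fold lower number from compound 1 to compound 3 (0.50 log units; beyond the scatter), the loss of a 3,4-dichlorobenzyl group did much the same. Compound 1 and compound 2 sit within the scatter of each other, so the two substituents on the ring nitrogen did not separate. Putting a (2,5-dichlorophenyl)sulfonyl group back on that nitrogen is therefore expected to move this assay upward by a modest step, a 2.6-fold higher number from compound 3 to compound 4 (0.41 log units; beyond the scatter), because of the step from compound 2 to compound 3 a 2.7-fold lower number from compound 2 to compound 3 (0.44 log units; beyond the scatter). Compound 4 is estimated at 50000 nM, within a range of 20000 nM to 120000 nM.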

Compound 4, half-maximal inhibitory concentration: > 100000 nM
Compound 4: only a limit was reported; the forecaster's own chance of this, stated with the estimate: 10%; middle value at least 2.0-fold (0.30 log units) from the limit.
By their numbers in this assay, from the lowest: compound 3; then compounds 2 and 1 (each within the scatter of the next). At a limit, above all of these: compound 4.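

Compound 4 is reported in this assay only as a limit: the limit of > 100000 nM in this assay, at which 1 of the 4 values shown sits.

Even read as a floor, the change on this amine nitrogen gives an at least 5.1-fold higher number from compound 3 to compound 4 (0.71 log units; beyond the scatter), so all three substituents shown on the ring nitrogen, with no exception among these compounds, carry higher numbers than the free amine of compound 3.

The earlier compounds shown here did not separate the substituents at this position, and compound 4 does not settle the matter either: the change on the sulfonyl sulfur gives an at least 1.8-fold higher number from compound 2 to compound 4 (0.27 log units; that floor lies within the scatter), and the exchange on the ring nitrogen gives an at least 1.6-fold higher number from compound 1 to compound 4 (0.21 log units; that floor lies within the scatter), so in both cases the floor stays within the scatter, while the limit leaves room for a larger true step.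

From the compounds shown here alone, it therefore remains open how far the 2,5-dichlorophenyl group raises the number relative to plain phenyl on the sulfonyl sulfur, since a limit puts no upper end on that step. The compounds shown also leave open whether a methyl or an acetyl group on that ring nitrogen would stay near compound 3 or rise with the larger groups.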